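The compounds below may be only part of what the source reports. "The series", "measured", "known", "first", "only" and "open" are said of these compounds alone.

Measured compounds:
- compound 1, `N[C@@H]1CCc2nc(-c3ccncc3)nc(Nc3cccc(F)c3)c2C1`, 1800 nM in a functional assay on G-361 cells (Homo sapiens) for antiproliferative activity, read by MTT assay, with a stated time of 72 h; on this read-out lower numbers stand for stronger inhibition and higher numbers for weaker inhibition
- compound 2, `COc1cccc(Nc2nc(-c3ccncc3)nc3c2CC(N)CC3)c1`, 6600 nM in this assay

Both compounds share the same core and differ only in the group carried on the aromatic ring of the aniline. Compound 2 stands as the higher of the two numbers, which means the weaker inhibitor of cell growth in this assay; compound 1 sits at a lower number, and the gap between them lies beyond the usual scatter, so the two are genuinely different.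

Compound 3, `NC1CCc2nc(-c3ccncc3)nc(Nc3cccc(F)c3)c2C1`, is the next compound to be measured. It is derived from compound 2 by one change: fluoro in place of methoxy on an aromatic carbon. The change sits on an aromatic carbon of a six-membered aromatic ring of carbon only, meta to a large group. In effect, compound 3 carries the same 3-fluorophenyl group that compound 1 carries, with the amine on the saturated ring left without a defined spatial arrangement.

Because compound 1 gives 1800 nM, the expected step of a 2.6-fold lower number from compound 2 to compound 3 (0.42 log units; beyond the scatter) is downward, a step beyond the scatter toward a stronger inhibitor. For compound 3 the estimated value is 2500 nM, with a range from 1000 nM to 6000 nM.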

Compound 3, half-maximal inhibitory concentration: 1400 nM
Compound 3: middle estimate off by 1.8-fold (0.25 log units), on the high side; measured number inside the range.
By their numbers in this assay, from the lowest: compounds 3 and 1 (each within the scatter of the next); then compound 2.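

Compounds 1 and 2 differ both in the aniline group and in how the amine carbon is drawn, so their gap could not be assigned to the aniline group alone. Compounds 2 and 3 are both drawn without a configuration at that carbon, so the change from 3-methoxyphenyl to 3-fluorophenyl can now be read by itself in this assay, as a 4.7-fold lower number from compound 2 to compound 3 (0.67 log units; beyond the scatter). The second comparison, a 1.3-fold lower number from compound 1 to compound 3 (0.11 log units; within the scatter), shows no separation between compound 1 and compound 3, and the only thing this pair can speak to is how the amine carbon is drawn: the fact that one of compounds 1 and 3 is drawn with a defined configuration and the other without, at the place where they differ

The compounds shown carry only methoxy and fluoro at this place on the ring, so it remains open whether chloro, methyl or a nitrile there would give a lower or a higher number, or one much the same. Also open, going by these compounds, is how a compound drawn with the opposite configuration at the amine carbon would read, and what would happen if a hydroxyl or an amide took the place of the amine.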